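Piperidine nitrogen substituent changes on a shared core

The compounds below may be only part of what the source reports. "The series", "measured", "known", "first", "only" and "open" are said of these compounds alone.

Compound 1 `CC(C)OC(=O)N1CCC(Oc2ncnc3c2CCN3c2ccc(S(C)(=O)=O)cc2F)CC1` carries an isopropoxycarbonyl group on the piperidine nitrogen; in a functional assay on CHO-K1 cells for agonist activity at Glucose-dependent insulinotropic receptor (Homo sapiens), read by a luciferase reporter, with a stated time of 5 h (a higher number here means that more compound is needed for the effect, a lower number that less compound is needed), compound 1 gives 50.1 nM. Compound 2 `CN(C)S(=O)(=O)N1CCC(Oc2ncnc3c2CCN3c2ccc(S(C)(=O)=O)cc2F)CC1`, with a dimethylsulfamoyl group in that place, gives 398 nM; the step of a 7.9-fold higher number from compound 1 to compound 2 (0.90 log units; beyond the scatter) is modest and beyond the scatter. Among the measured compounds shown here, compound 2 thus holds the highest of the two numbers so far.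

Compound 3 `CS(=O)(=O)c1ccc(N2CCc3c(OC4CCN(C5=NCCCN5)CC4)ncnc32)c(F)c1` changes the same position again: a group of 6 heavy atoms (4 carbon, 2 nitrogen; one six-membered non-aromatic ring with 2 hetero atoms) in place of a group of 6 heavy atoms (2 carbon, 1 nitrogen, 2 oxygen, 1 sulfur; no ring), on an amine nitrogen in a ring. For the measured compounds named here, the only measured step that bears on this position is a 7.9-fold higher number from compound 1 to compound 2 (0.90 log units; beyond the scatter), which shows that exchanging the group on this nitrogen can shift the number by a modest amount. Going by the values given here, for compound 3 the entering group has no measured precedent, so the expectation is a step of roughly a 2.0-fold lower number from compound 2 to compound 3 (0.30 log units; within the scatter), most likely within or near the scatter, with wide uncertainty. Compound 3 is therefore estimated at 200 nM, with a range from 40 nM to 1000 nM.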

Compound 3, half-maximal effective concentration: 2000 nM
The estimate for compound 3 lay 10-fold (1.00 log units) below the measured number; the measured number lies above the stated range.
By their numbers in this assay, from the lowest: compound 1; then compound 2; then compound 3.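

In this assay the group on the amine nitrogen in a ring can move the number much further than the first step showed: the entering ring, with 1 hydrogen-bond donor, gives a 5.0-fold higher number from compound 2 to compound 3 (0.70 log units; beyond the scatter) and, set against the isopropoxycarbonyl group, gives a 40-fold higher number from compound 1 to compound 3 (1.60 log units; beyond the scatter) in a step graded large. All three groups have the same heavy-atom count, so that count does not set the number in these compounds. No measurement available here accounts for the rise, and it cannot be assigned to any one feature of the entering group.

The ring and the hydrogen-bond donor change together in compound 3, so their separate contributions remain unresolved. Also open, going by these compounds, is how an open-chain guanidine would compare with this ring, and whether a tert-butoxycarbonyl group would give a number on either side of compound 1.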